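This account rests on a few compounds, and the source may have more. Where it says the series, first, only, none or still open, it means among the compounds named here.

Measured in a functional assay on HT cells (Homo sapiens) for antiproliferative activity, read by fluorescence, with a stated time of 72 h; a higher number here means a weaker inhibitor of growth, a lower number a stronger inhibitor of growth:
compound 1 `CCC(O)CSc1nc(NCc2ccc(-c3ccccn3)cc2)c2[nH]nc(C(C)C)c2n1` gives 273 nM
compound 2 `C=CCSc1nc(NCc2ccc(-c3ccccn3)cc2)c2[nH]nc(C(C)C)c2n1` gives 1010 nM
compound 3 `CC(C)c1n[nH]c2c(NCc3ccc(-c4ccccn4)cc3)nc(SCC(C)(C)O)nc12` gives 507 nM

Compound 1 holds the lowest of the three numbers in this assay. The nearest is a 1.9-fold higher number from compound 1 to compound 3 (0.27 log units; within the scatter), which stays within the scatter; the furthest is a 3.7-fold higher number from compound 1 to compound 2 (0.57 log units; beyond the scatter), a modest step beyond it.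

Compound 4 `CC(C)c1n[nH]c2c(NCc3ccc(-c4ccccn4)cc3)nc(SCC(C)(C)N)nc12` is the unmeasured member of the set. Its change from compound 1: 1-amino-1-methylethyl in place of 1-hydroxypropyl on a saturated chain carbon bound to a sulfur. Within the data shown here, two measured steps bear on this. a 1.9-fold higher number from compound 1 to compound 3 (0.27 log units; within the scatter) shows that 1-hydroxy-1-methylethyl in place of 1-hydroxypropyl on a saturated chain carbon bound to a sulfur is tolerated, so the carbon skeleton of the group entering in compound 4 is already covered. a 3.7-fold higher number from compound 1 to compound 2 (0.57 log units; beyond the scatter) shows that dropping the hydroxyl-bearing group for vinyl costs a modest step. Among the measured compounds shown here, the entering group of compound 4 matches the leaving group in what is counted, with nitrogen in place of oxygen, but no measured compound carries an amine at this place, so the direction is uncertain. The expected step is a 1.5-fold higher number from compound 1 to compound 4 (0.19 log units; within the scatter) in this assay, at the edge of the scatter, leaning toward a higher number. Compound 4 is estimated at 420 nM, with a range of 150 nM to 1200 nM.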

Compound 4, concentration for 50% growth inhibition: 85 nM
Compound 4: middle estimate off by 4.9-fold (0.69 log units), on the high side; the measured number lies below the stated range.
By their numbers in this assay, from the lowest: compound 4; then compounds 1, 3 and 2 (each within the scatter of the next, the first and the last beyond it).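

In this assay, the pair with the same carbon skeleton isolates the exchange of hydroxy for amino on a saturated chain carbon bound to three saturated chain carbons, and it gives a 6.0-fold lower number from compound 3 to compound 4 (0.78 log units; beyond the scatter), so the heteroatom at this place affects the read-out even though what is counted under donors and acceptors stays the same. The earlier compounds shown here showed only that the 1-hydroxypropyl and 1-hydroxy-1-methylethyl groups could not be separated and that vinyl stood above 1-hydroxypropyl; the amine now sets a new low for the set, with a 3.2-fold lower number from compound 1 to compound 4 (0.51 log units; beyond the scatter) and, against the vinyl compound, a large 12-fold lower number from compound 2 to compound 4 (1.07 log units; beyond the scatter). Nothing given here accounts for the advantage of amino over hydroxy at this place.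

The compounds shown leave open whether the gain belongs to the amine alone or needs the branched skeleton, a question that 2-aminobutyl, carrying the amine on the chain of compound 1, would address. Also open, from the compounds shown here alone, is how far the nitrogen tolerates substitution, as in a 2-(methylamino)-2-methylpropyl or 2-(dimethylamino)-2-methylpropyl group, or replacement by a carboxylic acid.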